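Trimming the Triazole Ester Down to a Primary Amine

The compounds below may be only part of what the source reports. "The series", "measured", "known", "first", "only" and "open" are said of these compounds alone.

Measured compounds:
compound 1 `NS(=O)(=O)c1cc(-c2nnc(CN3CCN(c4ccc(Cl)cc4)CC3)o2)c(Cl)cc1SCc1ccccc1`, 280000 nM
compound 2 `CCOC(=O)c1cn(Cc2nnc(-c3cc(S(N)(=O)=O)c(SCc4ccccc4)cc3Cl)o2)nn1`, 150000 nM

In a functional assay on MCF7 cells (Homo sapiens) for cytotoxicity, read by MTT assay, with a stated time of 72 h (a higher number here means a weaker inhibitor, a lower number a stronger inhibitor), compound 2 gives 150000 nM, the lower of the two numbers shown, while compound 1 gives 280000 nM. The two values sit within the scatter of each other, so neither compound can be set above the other on this evidence. Compound 3 `NCc1nnc(-c2cc(S(N)(=O)=O)c(SCc3ccccc3)cc2Cl)o1` has not yet been measured in this assay. It differs from compound 2 in a single place: amino in place of 4-(ethoxycarbonyl)-1H-1,2,3-triazol-1-yl on a saturated chain carbon bound to an aromatic carbon. For the measured compounds named here, no step between measured compounds shows how a change of this kind plays out here, and the two numbers available both lie in the weak range. With nothing to anchor a direction, one expects no step beyond the scatter from compound 2 to compound 3, with a slight lean toward a higher number as the more likely outcome if any move appears. The estimate for compound 3 in this assay is 220000 nM, expected to fall between 70000 nM and 700000 nM. The step this estimate implies is expected to be a 1.5-fold higher number from compound 2 to compound 3 (0.17 log units; within the scatter).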

Compound 3, half-maximal inhibitory concentration: 135000 nM
The estimate for compound 3 lay 1.6-fold (0.21 log units) above the measured number, within the range that was stated.
By their numbers in this assay, from the lowest: compounds 3, 2 and 1 (each within the scatter of the next, the first and the last beyond it).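

In this assay, putting amino in place of 4-(ethoxycarbonyl)-1H-1,2,3-triazol-1-yl on a saturated chain carbon bound to an aromatic carbon gives a 1.1-fold lower number from compound 2 to compound 3 (0.05 log units; within the scatter). For the compounds shown here, this is the first step that can be read at this position. The group that leaves has 10 heavy atoms, with its five-membered aromatic ring and its ester, and the group that enters has 1 heavy atom. The step lies within the scatter. Compound 3 gives 135000 nM, a number that cannot be told apart from that of compound 2. Nothing at hand explains why so large a change in the group leaves the reading within the scatter.

From the compounds shown here alone, it remains open whether any group at this position can bring the number out of this weak range, for example a carboxylic acid in place of the ethyl ester on the triazole, an acetamide on the amino nitrogen, or a longer chain ending in a primary amine. Going by these compounds, it is also open whether a change elsewhere on the shared core, such as a methyl group in place of the benzyl group on sulfur, would matter more than this position does.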